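This account rests on a few compounds, and the source may have more. Where it says the series, first, only, none or still open, it means among the compounds named here.

Measured compounds:
compound 1, `CC#C[C@H]1CN(S(=O)(=O)c2ccc(N)nc2)CCN1c1ccc(S(=O)(=NC)C(F)(F)F)cc1`, 2060 nM
compound 2, `CC#C[C@H]1CN(S(=O)(=O)c2ccc(N)nc2)CCN1c1ccc(S(=O)(=O)NCC2CC2)cc1`, 271 nM
compound 3, `CC#C[C@H]1CN(S(=O)(=O)c2ccc(N)nc2)CCN1c1ccc(S(C)(=N)=O)cc1`, 704 nM

All three share one core and differ only in the substituent on the aromatic carbon of the six-membered carbon ring. In an assay on cells (Hepatocyte) for inhibition of glucokinase regulatory protein (Mus musculus), with stated times of 20 min and 40 min (on this read-out lower numbers stand for an effect already at smaller amounts and higher numbers for an effect only at larger amounts of compound), compound 3 gives 704 nM, the second highest of the three numbers, its nearest neighbour being compound 2 and its furthest compound 1.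

Compound 4, `CC#C[C@H]1CN(S(=O)(=O)c2ccc(N)nc2)CCN1c1ccc(C(O)(CC#N)C(F)(F)F)cc1`, is compound 3 with a group of 9 heavy atoms (4 carbon, 1 nitrogen, 1 oxygen, 3 fluorine; no ring) in place of a group of 4 heavy atoms (1 carbon, 1 nitrogen, 1 oxygen, 1 sulfur; no ring), on an aromatic carbon. Within the data shown here, the incoming group is not present in any measured compound, so no step matches it directly. Among the measured compounds shown here, the steps that bear on this position are a 2.9-fold lower number from compound 1 to compound 3 (0.47 log units; beyond the scatter) and a 2.6-fold higher number from compound 2 to compound 3 (0.41 log units; beyond the scatter), together with a 7.6-fold lower number from compound 1 to compound 2 (0.88 log units; beyond the scatter); all are modest and show that exchanging the group on this carbon moves this assay by a small-to-moderate amount in either direction. With nothing to favour one direction, a step of about a 1.1-fold higher number from compound 3 to compound 4 (0.06 log units; within the scatter) is expected, i.e. near to no change beyond the scatter, with wide uncertainty. Compound 4 is therefore estimated at 800 nM, range 200 nM to 3000 nM.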

Compound 4, half-maximal effective concentration: 219 nM
Beside the measured number, compound 4's estimate is 3.7-fold (0.56 log units) above it; measured number inside the range.
By their numbers in this assay, from the lowest: compounds 4 and 2 (each within the scatter of the next); then compound 3; then compound 1.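

Notes on the group on the aromatic carbon, read in this assay: sulfur in this group is not needed for the lower numbers, since a 3.2-fold lower number from compound 3 to compound 4 (0.51 log units; beyond the scatter) and a 1.2-fold lower number from compound 2 to compound 4 (0.09 log units; within the scatter), leaving compound 4 level with compound 2 despite a group with no sulfur and no ring. Three fluorine atoms in the group also do not go with a high number on their own, as a 9.4-fold lower number from compound 1 to compound 4 (0.97 log units; beyond the scatter), and heavy-atom count does not order the series, with compound 1 going against any trend from the smallest group of compound 3 to the largest of compound 4. No measurement at hand accounts for these steps.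

Still open, as far as these compounds go, is which part of the new group carries the step: the hydroxyl, the trifluoromethyl or the nitrile-bearing chain. Also open, from the compounds shown here alone, is how a carboxylic acid, an amine or a longer chain would read on this carbon.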